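The source may report more compounds than this note shows. Statements on the series, on what has been measured and on what is new or still open speak of the compounds shown alone.

Measured compounds:
compound 1, `CS(=O)(=O)N1CCN(c2cc(NCCN)c3ccccc3n2)CC1`: > 100000 nM
compound 2, `NCC(O)CNc1cc(N2CCC(c3ccccc3)CC2)nc2ccccc12`: 20800 nM

Both compounds were tested in an ADME assay on HEp-2 cells (Homo sapiens) for cytotoxicity, read by CCK-8 assay, with a stated time of 6 days; a higher number here means that more compound is tolerated, a lower number that less compound is tolerated. For compound 1 the reading is > 100000 nM, which is a limit of the assay rather than a number, so compound 1 is known only to sit at the limit of > 100000 nM in this assay, at which 1 of the 2 values shown sits. In this assay compound 2 gives 20800 nM. Among the measured compounds shown here, these two compounds differ in more than one place, so no single step joins them; their two values show only that a number is at hand for compound 2 alone.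

Compound 3, `NCCNc1cc(N2CCN(c3ccc(Cl)cc3)CC2)nc2ccccc12`, has not yet been measured in this assay. It comes from compound 1 through one change: 4-chlorophenyl in place of methylsulfonyl on an amine nitrogen in a ring. For the measured compounds named here, no measured step of this kind exists here, so the expected size must be guessed. Going by the values given here, the expectation is a step beyond the usual scatter toward less compound being tolerated, since compound 2, the only compound here with a number, gives 20800 nM. Compound 3 is therefore expected to give about 30000 nM, within 8000 nM to 100000 nM. The expected step of an at least 3.3-fold lower number from compound 1 to compound 3 (0.52 log units; beyond the scatter) is what this estimate means.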

Compound 3, half-maximal cytotoxic concentration: 6600 nM
Estimate against measurement, compound 3: 4.5-fold (0.66 log units) above; measured number below the stated range.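

In this assay, among the compounds shown here, the single change at the amine nitrogen of the six-membered non-aromatic ring gives an at least 15-fold lower number from compound 1 to compound 3 (1.18 log units; beyond the scatter), the first comparison here in which only one place differs. It shows that the group on this nitrogen is not a neutral detail: with 4-chlorophenyl there in place of methylsulfonyl, the cells tolerate clearly less compound, although the rest of the molecule stays the same. The full size of this step remains unknown, because the reading for compound 1 is a limit and not a number: the limit of > 100000 nM in this assay, at which 1 of the 3 values shown sits.

The change replaces a group with no ring and two hydrogen-bond acceptors by a six-membered aromatic ring of carbon only that also carries chlorine, so this one pair cannot show which of these differences matters, or whether the step would hold on another core. A plain phenyl, a 4-methoxyphenyl or an acetyl group on the same nitrogen would help to separate the part played by the aromatic ring from that of the chlorine atom.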